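The source may hold more compounds than are shown below. What is called first, only, known or untested is meant among the compounds shown, and "the series" means these compounds.

Compound 1 `O=C(N/N=C/c1ccccc1)c1cccnc1` and compound 2 `O=C(N/N=C/c1ccc(F)cc1)c1cccnc1` share one core. In an ADME assay on HEL cells (Homo sapiens) for cytotoxicity, read by microscopy (on this read-out higher numbers stand for lower toxicity in this test and lower numbers for higher toxicity in this test), compound 1 gives > 100 ug/mL, which is a limit of the assay and not a number. Compound 2 likewise gives > 100 ug/mL in this assay, again only a limit. The step that the two limits leave unreadable from compound 1 to compound 2 therefore cannot be read, since the limit of > 100 ug/mL in this assay, at which 2 of the 2 values shown sit, holds both values. Compound 3 `O=C(N/N=C/c1ccc([N+](=O)[O-])cc1)c1cccnc1` carries the change (nitro in place of fluoro on an aromatic carbon). Among the compounds with values here, no measured step bears on this change, so no step beyond the scatter is expected in either direction in this assay. For compound 3 an estimate of 100 ug/mL, between 50 ug/mL and 200 ug/mL, is expected. For compound 3 the expected step is a number no higher from compound 2 to compound 3 (the limit leaves the size open).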

Compound 3, minimum cytotoxic concentration: >= 0.8 ug/mL
Compound 3: a limit, no number; the forecaster's own chance of this, stated with the estimate: 85%; the middle value is on the limit's open side.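

Compound 3 gives only a limit, as do compound 1 and compound 2, so no step among these compounds can be read. The compounds shown leave open whether nitro, fluoro or hydrogen at this place makes any difference in this assay.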